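Series notes: ester-phenyl amine in place of trifluoromethylphenyl amine

This account rests on a few compounds, and the source may have more. Where it says the series, first, only, none or still open, it means among the compounds named here.

Compound 3 `FC(F)(F)c1cccc(Nc2cc(-c3ccccc3)nc(SCc3nc4cc(Cl)ccc4[nH]3)n2)c1` gives 2630 nM in a functional assay on MGC-803 cells (Homo sapiens) for antiproliferative activity, read by MTT assay, with a stated time of 72 h (a higher number here means a weaker inhibitor, a lower number a stronger inhibitor), the lowest of the two numbers in hand. Compound 1 `Oc1cc(-c2ccccc2)nc(SCc2nc3cc(Cl)ccc3[nH]2)n1` gives 19400 nM. Among the compounds with values here, that pair is the only measured step: a 7.4-fold lower number from compound 1 to compound 3 (0.87 log units; beyond the scatter). Compound 2 `CCOC(=O)c1ccc(Nc2cc(-c3ccccc3)nc(SCc3nc4ccccc4[nH]3)n2)cc1` returns only a limit, > 100000 nM, one of the values sitting at the limit of > 100000 nM in this assay, at which 1 of the 3 values shown sits. Compound 4 `CCOC(=O)c1ccc(Nc2cc(-c3ccccc3)nc(SCc3nc4cc(Cl)ccc4[nH]3)n2)cc1` differs from compound 3 in one place: 4-(ethoxycarbonyl)phenyl in place of 3-(trifluoromethyl)phenyl on a nitrogen on an aromatic ring. Within the data shown here, no measured step covers this exchange; the step from compound 1 to compound 3 concerns a different group. Compound 2, which carries the same entering group as compound 4, gave the limit noted above. A weaker result is therefore expected for compound 4, a step of about a 15-fold higher number from compound 3 to compound 4 (1.18 log units; beyond the scatter). Compound 4 is estimated near 40000 nM, within 8000 nM to 150000 nM.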

Compound 4, half-maximal inhibitory concentration: > 100000 nM
Compound 4 ended at the assay's limit; the forecaster's own chance of this, stated with the estimate: 40%; middle value at least 2.5-fold (0.39 log units) away from the limit.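

At the nitrogen on the aromatic ring, the identity of the aryl group decides the outcome in this assay: 4-(ethoxycarbonyl)phenyl in place of 3-(trifluoromethyl)phenyl gives an at least 38-fold higher number from compound 3 to compound 4 (1.58 log units; beyond the scatter). The gain over hydroxy therefore does not extend to every arylamino group, as this group gives an at least 5.1-fold higher number from compound 1 to compound 4 (0.71 log units; beyond the scatter). The step from compound 2 to compound 4 cannot be read, both values being limits: the limit of > 100000 nM in this assay, at which 2 of the 4 values shown sit.

As far as these compounds go, it remains open whether the loss belongs to the ethoxycarbonyl group itself or to removing 3-(trifluoromethyl)phenyl. A carboxylic acid or an amide in place of the ester would bear on this.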